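This account rests on a few compounds, and the source may have more. Where it says the series, first, only, none or still open, it means among the compounds named here.

Measured compounds in a functional assay on Raji cells (Homo sapiens) for antiproliferative activity, read by CCK-8 assay, with a stated time of 72 h, tested at 40 uM; on this read-out lower numbers stand for less inhibition and higher numbers for more inhibition at the one concentration tested (going by the name of the read-out):
- compound 1 `CCOC(=O)c1sc(-c2cccc(NC(=O)c3ccc(C(F)(F)F)cc3)c2)nc1Nc1ccc(N2CCN(C)CC2)cc1`: 33%
- compound 2 `CCOC(=O)c1sc(-c2cccc(NC(=O)c3ccccc3)c2)nc1Nc1ccc(N2CCN(C)CC2)cc1`: 42%
- compound 3 `CCOC(=O)c1sc(-c2cccc(NC(=O)c3cccc(F)c3)c2)nc1Nc1ccc(N2CCN(C)CC2)cc1`: 82.8%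

Compound 3 gives the highest number of the three in this assay; compound 2 lies a number 40.8 percentage points higher from compound 2 to compound 3 (beyond the scatter) and compound 1 lies a number 49.8 percentage points higher from compound 1 to compound 3 (beyond the scatter), both beyond the scatter. Compound 1 and compound 2 differ by a number 9 percentage points higher from compound 1 to compound 2 (within the scatter), within the scatter.

Compound 4 `CCOC(=O)c1sc(-c2cccc(NC(=O)c3ccco3)c2)nc1Nc1ccc(N2CCN(C)CC2)cc1` differs from compound 3 in furan-2-yl in place of 3-fluorophenyl on a carbonyl carbon. Among the measured compounds shown here, no measured step shows furan-2-yl; the two changes made at this carbonyl carbon, 1>3 and 2>3, were both large, so a sizeable step from compound 3 is possible in either direction, with a drop judged more likely than a further rise. Compound 4 is therefore expected near 50%, between 20% and 85%, an expected step of a number 32.8 percentage points lower from compound 3 to compound 4 (beyond the scatter).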

Compound 4, a percentage reported as inhibition, at one concentration (the size of the read-out at that concentration, not a potency): 87.6%
Compound 4: the middle estimate sits 37.6 percentage points below what was measured; measured number outside the range, above it.
By their numbers in this assay, from the lowest: compounds 1 and 2 (each within the scatter of the next); then compounds 3 and 4 (each within the scatter of the next).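

In this assay the carbonyl carbon accepts a five-membered aromatic ring with a hetero atom as well as 3-fluorophenyl: the change gives a number 4.8 percentage points higher from compound 3 to compound 4 (within the scatter) and so leaves the two level. The high number therefore does not need a phenyl ring at this position, since furan-2-yl gives a number 45.6 percentage points higher from compound 2 to compound 4 (beyond the scatter) and a number 54.6 percentage points higher from compound 1 to compound 4 (beyond the scatter) against the two lower compounds. Nothing available explains why these two different groups read alike.

Open, from the compounds shown here alone, is whether thiophen-2-yl or a saturated ring such as cyclohexyl on this carbonyl carbon would read like compound 4. A single concentration also leaves the potency of compound 3 and compound 4 open.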